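A few compounds are considered here, and "the series" means these few. Any claim that something is new, unique, unknown or untested is made for them only; others in the source may bear on it.

Compound 1, `CCOC(=O)c1cc(-c2cc(OC)c(OC)c(OC)c2)c(-c2ccc(OC)cc2)s1`, is a thiophene-based structure carrying an ester and two substituted phenyl groups. In a functional assay on SGC-7901 cells (Homo sapiens) for antiproliferative activity, read by MTT assay, with a stated time of 72 h (a lower number here means a stronger inhibitor, a higher number a weaker inhibitor), compound 1 gives 9760 nM. Compound 2, `CCOC(=O)c1cc(-c2cc(OC)c(OC)c(OC)c2)c(-c2ccc(OC)c([N+](=O)[O-])c2)s1`, differs from it in one place: nitro in place of hydrogen on an aromatic carbon. That single change gave a 1.9-fold higher number from compound 1 to compound 2 (0.27 log units; within the scatter), so compound 2 with its reading of 18100 nM cannot be told apart from compound 1 on this measurement alone.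

Compound 3, `COc1ccc(-c2ccsc2-c2cc(OC)c(OC)c(OC)c2)cc1`, lacks the ester and shares only part of its framework with compound 1; the difference between the two cores is not broken down here. In this assay compound 3 gives 2740 nM, the lowest of the three numbers and beyond the scatter from both compound 1 and compound 2, so compound 3 is the strongest inhibitor of the three.

Compound 4, `COc1ccc(-c2ccsc2-c2cc(OC)c(OC)c(OC)c2)cc1[N+](=O)[O-]`, has not yet been measured. It stands to compound 3 exactly as compound 2 stands to compound 1: nitro in place of hydrogen on an aromatic carbon. The surroundings of the change are the same in both pairs, so this is the same change applied to a different core. Going by the values given here, since the only example of this change on record is the step from compound 1 to compound 2, the expectation for compound 4 is a step of about the same size, that is a 1.9-fold higher number from compound 3 to compound 4 (0.28 log units; within the scatter), resting on a 1.9-fold higher number from compound 1 to compound 2 (0.27 log units; within the scatter). On that basis compound 4 is estimated to give 5200 nM in this assay, with a plausible range from 2500 nM to 11000 nM.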

Compound 4, half-maximal inhibitory concentration: 10300 nM
Compound 4: middle estimate off by 2.0-fold (0.30 log units), on the low side; the range from low to high includes it.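

Adding the nitro group to the core of compound 3 gives a 3.8-fold higher number from compound 3 to compound 4 (0.58 log units; beyond the scatter) in this assay, so this pair, unlike the first, is separated by more than the usual variation between repeated measurements. Going by these compounds alone, the two steps on the two cores cannot be told apart, so nothing here shows that the core alters the size of what this change does: the same change on two cores in this assay, a 1.9-fold higher number (0.27 log units; within the scatter) from compound 1 to compound 2 and a 3.8-fold higher number (0.58 log units; beyond the scatter) from compound 3 to compound 4, 2.0-fold (0.31 log units) apart, within the scatter of two such steps This does not establish a fixed step size or a general rule, since it rests on only two pairs, the first of which lies within the scatter on its own, and it gives no explanation of why the number rises from compound 3 to compound 4.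

The compounds shown leave open whether another group, such as an amine, a nitrile or a fluorine atom, would give a different result on an aromatic carbon ortho to a methoxy group, and whether any such group would behave alike on both cores. They also leave open how the ester itself contributes, which a carboxylic acid or an amide in its place on an otherwise unchanged core could begin to answer.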